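This account rests on a few compounds, and the source may have more. Where it says the series, first, only, none or still open, it means among the compounds named here.

Among the compounds with values here, compound 1 `CCOc1cc2nc(CCC(C)(C)C(=O)NCCOCCOCCNc3cccc4c3C(=O)N(C3CCC(=O)N(C)C3=O)C4=O)n(C)c2cc1NC(=O)c1cccc(C(F)(F)F)n1` is the only compound here with a methyl on the amide-type nitrogen in the ring of its six-membered non-aromatic ring. In a functional assay on TMD8 cells (Homo sapiens) for inhibition, read by CCK-8 assay, with a stated time of 72 h (a lower number here means a stronger inhibitor, a higher number a weaker inhibitor), compound 1 gives > 50000 nM, which is a limit of the assay and not a measured number. Compound 2 `CCOc1cc2nc(CCC(C)(C)C(=O)OC)n(C)c2cc1NC(=O)c1cccc(C(F)(F)F)n1` shares the core of compound 1 but ends in a methyl ester instead of the long chain. In this assay compound 2 gives > 50000 nM, again a limit. Where compound 1 stands can thus be said only loosely: it sits at the limit of > 50000 nM in this assay, at which 2 of the 2 values shown sit, and no measured compound yields a number against which a step could be sized. The change from compound 1 to the unmeasured compound 3 `CCOc1cc2nc(CCC(C)(C)C(=O)NCCOCCOCCNc3cccc4c3C(=O)N(C3CCC(=O)NC3=O)C4=O)n(C)c2cc1NC(=O)c1cccc(C(F)(F)F)n1` is hydrogen in place of methyl on an amide-type nitrogen in a ring, a change of a single carbon on the amide-type nitrogen in the ring, two ring bonds from the ring atom that bears a large group. Within the data shown here, with no measured step in hand, the size of the step of an at least 830-fold lower number from compound 1 to compound 3 (2.92 log units; beyond the scatter) is an expectation only, and it is expected to run toward stronger inhibition, well beyond the usual scatter. Compound 3 is estimated at 60 nM, expected to fall between 5 nM and 2000 nM.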

Compound 3, half-maximal inhibitory concentration: 7600 nM
The estimate for compound 3 lay 130-fold (2.10 log units) below the measured number, and the stated range ends below it.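

Within the data shown here, replacing the methyl with hydrogen on the amide-type nitrogen in the ring is the first change in this set that can be read as a step: in this assay it gives an at least 6.5-fold lower number from compound 1 to compound 3 (0.81 log units; beyond the scatter), so this place, two ring bonds from the ring atom that bears a large group, has a bearing on the read-out. Among these compounds, with the 2,6-dioxopiperidin-3-yl group in place of the 1-methyl-2,6-dioxopiperidin-3-yl group, compound 3 gives 7600 nM, the first actual number in this assay. The true size of the step stays unknown, since the value of compound 1 is a limit of the assay and not a number: the limit of > 50000 nM in this assay, at which 2 of the 3 values shown sit.

As far as these compounds go, whether an ethyl group or a longer chain on that same nitrogen would give a number close to that of compound 3 or one back at the limit remains open. Also open, from the compounds shown here alone, is how far the number of compound 3 would move if its long chain were replaced by a shorter or longer one, with the hydrogen kept on the nitrogen.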